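A few compounds are considered here, and "the series" means these few. Any claim that something is new, unique, unknown or untested is made for them only; others in the source may bear on it.

Measured so far:
- compound 1, `COc1ccc(/C=C/C(=O)c2cc3ccc(OCc4cccc(OC)c4)cc3oc2=O)cc1`: > 100000 nM
- compound 2, `COc1cccc(/C=C/C(=O)c2cc3cc(OCc4ccccc4)ccc3oc2=O)c1OC`: 23600 nM

In a functional assay on MOLT-4 cells (Homo sapiens) for cytotoxicity, read by MTT assay, with a stated time of 72 h (on this read-out higher numbers stand for weaker inhibition and lower numbers for stronger inhibition), compound 1 sits at a limit, not a number: > 100000 nM. This is the limit of > 100000 nM in this assay, at which 1 of the 2 values shown sits. Among the compounds with values here, compound 2 gives a measured value in this assay, 23600 nM; no step between compound 1 and compound 2 is counted, as the two differ in more than one place.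

Compound 3, `COc1cccc(COc2ccc3cc(C(=O)/C=C/c4cccc(OC)c4OC)c(=O)oc3c2)c1`, is not yet measured. It differs from compound 1 by 2,3-dimethoxyphenyl in place of 4-methoxyphenyl on a double-bonded chain carbon bound to a double-bonded chain carbon. Within the data shown here, no measured step covers this change. Among the measured compounds shown here, compound 2, the only compound with a measured number here, also carries the 2,3-dimethoxyphenyl on the double-bonded chain carbon, so a number rather than a limit is thought plausible for compound 3, though a limit remains a real possibility.

The step from compound 1 to compound 3 is expected to be an at least 2.5-fold lower number from compound 1 to compound 3 (0.39 log units; beyond the scatter) in this assay. Compound 3 is estimated at 40000 nM, within 15000 nM to 120000 nM.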

Compound 3, half-maximal inhibitory concentration: 22800 nM
For compound 3 the middle estimate is 1.8-fold (0.24 log units) above the measured one; the measured number falls inside the stated range.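

In this assay, 2,3-dimethoxyphenyl in place of 4-methoxyphenyl on a double-bonded chain carbon bound to a double-bonded chain carbon gives an at least 4.3-fold lower number from compound 1 to compound 3 (0.64 log units; beyond the scatter). Compound 3 gives 22800 nM, so this single change, with the rest of the structure of compound 1 held, is enough to give a measured number. The step has a lower bound only, because compound 1 stands at a limit and not at a number: the limit of > 100000 nM in this assay, at which 1 of the 3 values shown sits.

On these data alone, how much of the step belongs to the extra methoxy and how much to the changed arrangement of the methoxy groups stays open, as does the full size of the step. Also open, as far as these compounds go, is how this position reads with an aromatic ring carrying an amine or a carboxylic acid.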